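Geometric isomer of compound 3: cytotoxicity expectation

The source may report more compounds than this note shows. Statements on the series, on what has been measured and on what is new or still open speak of the compounds shown alone.

Measured compounds:
- compound 1 `CC(C)CC(=O)O[C@@H]1OC=C(CO[C@@H]2O[C@H](CO)[C@@H](O)[C@H](O)[C@H]2OC(=O)/C=C/c2ccc(O)cc2)[C@H]2CC[C@](O)(CO)[C@@H]12`: > 10000 nM
- compound 2 `CC(C)CC(=O)O[C@@H]1OC=C(CO[C@@H]2O[C@H](CO)[C@@H](O)[C@H](O)[C@H]2OC(=O)/C=C\c2ccc(O)cc2)[C@H]2CC[C@](O)(CO)[C@@H]12`: > 10000 nM
- compound 3 `CC(=O)OC[C@@]1(O)CC[C@@H]2C(CO[C@@H]3O[C@H](CO)[C@@H](O)[C@H](O)[C@H]3OC(=O)/C=C/c3ccc(O)cc3)=CO[C@@H](OC(=O)CC(C)C)[C@@H]21`: > 10000 nM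

In a functional assay on A549 cells (Homo sapiens) for cytotoxicity, read by sulforhodamine B assay, with a stated time of 48 h (on this read-out lower numbers stand for stronger inhibition and higher numbers for weaker inhibition), compound 1 reaches only the limit of the assay, > 10000 nM. Compound 2 likewise gives a limit, > 10000 nM. Compound 3 also gives a limit, > 10000 nM. Compound 3 therefore stands where every value in this set stands, at the limit, and no number separates it from the other two (the limit of > 10000 nM in this assay, at which 3 of the 3 values shown sit).

Compound 4 `CC(=O)OC[C@@]1(O)CC[C@@H]2C(CO[C@@H]3O[C@H](CO)[C@@H](O)[C@H](O)[C@H]3OC(=O)/C=C\c3ccc(O)cc3)=CO[C@@H](OC(=O)CC(C)C)[C@@H]21` differs from compound 3 as follows: the two compounds have the same atoms and bonds and differ only in configuration as drawn: 1 of 10 stereo elements differ; a double bond is drawn E in compound 3 and Z in compound 4. The measured steps bearing on this are a step that the two limits leave unreadable from compound 1 to compound 2, where the same kind of change occurs (the fact that compounds 1 and 2 differ only in the configuration as drawn), and a step that the two limits leave unreadable from compound 1 to compound 3, which carries the acetyl that compound 3 and compound 4 share. Neither step yields a readable size, since both ends of each sit at the limit. Between compound 1 and compound 2, the change from E to Z did not bring either compound below the limit; the same outcome is expected here.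

For compound 4 the expected step is a step that the limit leaves unreadable from compound 3 to compound 4, meaning nothing beyond the scatter. Compound 4 is estimated at 20000 nM, in the range 10000 nM to 100000 nM, most likely reported only as a limit again.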

Compound 4, half-maximal inhibitory concentration: > 10000 nM
Compound 4 ended at the assay's limit; the forecaster's own chance of this, stated with the estimate: 90%; the middle value does not contradict the limit.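

In this assay compound 4 gives > 10000 nM, a limit and not a number. For the compounds shown here, no step among compounds 1, 2, 3 and 4 can be read, neither for the E to Z change nor for the acetyl: the limit of > 10000 nM in this assay, at which 4 of the 4 values shown sit. The compounds shown leave open whether either change matters in a compound that gives a value short of the limit.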